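The compounds below may be only part of what the source reports. "The series", "measured", "known", "first", "only" and "open" are said of these compounds alone.

Measured in an ADME assay on the whole organism (strain ICR) for pharmacokinetics, with Mus musculus as the target, using cassette dosing, at a dose of 1 mg/kg by the oral route; a higher number here means that a larger share of the oral dose reaches the circulation, a lower number that a smaller share of the oral dose reaches the circulation:
Compound 1 `O=C(c1c[nH]c(=O)c2ccccc12)N1CCN(C(=O)c2ccc(Br)cc2)[C@@H](c2ccc(Cl)cc2)C1`: 9.6%
Compound 2 `O=C(c1cc(-c2cccc(C(F)(F)F)c2)c(=O)n(-c2ccccc2)c1)N1CCN(C(=O)c2ccc(Br)cn2)[C@@H](c2ccc(Cl)cc2)C1`: 23.7%
Compound 3 `O=C(c1cnn2cc(Br)ccc12)N1CCN(C(=O)c2ccc(Br)cn2)[C@@H](c2ccc(Cl)cc2)C1`: 11.4%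

Compound 1 and compound 3 lie within the scatter of each other, while compound 2 stands beyond the scatter, higher than compound 1. The next compound to be tested, compound 4 `O=C(c1ccnc2ccccc12)N1CCN(C(=O)c2ccc(Br)cc2)[C@@H](c2ccc(Cl)cc2)C1`, keeps the rest of compound 1 and changes one group on a carbonyl carbon whose other neighbours are: amide-type nitrogen in a ring. There, quinolin-4-yl enters in place of a group with no common name: a group of 10 heavy atoms (9 carbon, 1 nitrogen; one six-membered aromatic ring of carbon only, one six-membered aromatic ring with 1 hetero atom) in place of a group of 11 heavy atoms (9 carbon, 1 nitrogen, 1 oxygen; one six-membered aromatic ring of carbon only, one six-membered aromatic ring with 1 hetero atom), on a carbonyl carbon.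

Among the compounds with values here, no two measured compounds differ in one place only, so the data offer no direct measure of such a step. A small upward step, within the scatter, is expected, an expectation that leans on compound 1 at 9.6% and on compound 3 at 11.4%. The expected step is a number 4.4 percentage points higher from compound 1 to compound 4 (within the scatter). For compound 4 the estimated value is 14%, with an expected range from 5% to 30%.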

Compound 4, oral bioavailability in the Mus musculus assay: 19.7%
Beside the measured number, compound 4's estimate is 5.7 percentage points below it, and the stated range covers the measured number.
By their numbers in the Mus musculus assay, from the lowest: compounds 1, 3, 4 and 2 (each within the scatter of the next, the first and the last beyond it).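

Within the data shown here, at this position on the carbonyl carbon, the step gives the first direct reading of a single change. When quinolin-4-yl, which has no hydrogen-bond donor, replaces the group that carries one, the Mus musculus assay shows a number 10.1 percentage points higher from compound 1 to compound 4 (beyond the scatter). In a physicochemical assay for solubility, at pH 6.8 (a higher number here means a more soluble compound, a lower number a less soluble compound), where compound 1 gives 11 ug/mL and compound 4 gives 3.2 ug/mL, the same change runs the other way: the measured solubility of compound 1, 11 ug/mL, and of compound 4, 3.2 ug/mL, a 3.4-fold lower number (0.54 log units; beyond the scatter). For this pair, therefore, a larger share of the oral dose reaches the circulation even though solubility is lower.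

This single step cannot show whether the rise follows from losing the hydrogen-bond donor, from the change in the ring itself, or from some other effect of the swap. It also leaves open whether another group on this carbonyl carbon, such as a quinoline carrying an amine or a carboxylic acid, would keep the higher bioavailability and recover solubility.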